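The compounds below may be only part of what the source reports. "The series", "measured", "known", "first", "only" and "open" are said of these compounds alone.

Measured so far in a physicochemical assay for solubility, read by HPLC, using the shake flask method, in phosphate buffer, with a stated time of 20 h, at pH 6.5; a lower number here means a less soluble compound, a higher number a more soluble compound

Compound 1 `C[C@@H]1CN(c2nccc3[nH]c(-c4ccc(F)c(F)c4)nc23)C[C@H](C)N1` gives 190000 nM
Compound 2 `CN1CCN(C(=O)C2CCN(c3nccc4[nH]c(-c5ccc(F)c(F)c5)nc34)CC2)CC1` gives 200000 nM
Compound 3 `NC1CCN(c2nccc3[nH]c(-c4cccc(OC(F)(F)F)c4)nc23)CC1` gives 200000 nM

Compound 3 stands level with compound 2 at the digits shown, and compound 1 lies within the scatter of both. Compound 4 `CN(C)C1CCN(c2nccc3[nH]c(-c4cccc(OC(F)(F)F)c4)nc23)CC1`, not yet measured, carries dimethylamino in place of amino on a saturated ring carbon relative to compound 3. Within the data shown here, no measured pair differs in one place only, so no direct precedent exists. Compound 1 at 190000 nM and compound 2 at 200000 nM carry other groups than compound 3 yet stay within the scatter of it, so no step beyond the scatter is expected in this assay here. The estimated step of a 1.1-fold lower number from compound 3 to compound 4 (0.05 log units; within the scatter) stays within the scatter. Compound 4 is estimated at 180000 nM (expected range 90000 nM to 300000 nM).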

Compound 4, solubility: 180000 nM
For compound 4 middle estimate and measured number coincide at the digits printed, within the range that was stated.
By their numbers in this assay, from the lowest: compounds 4, 1, 2 and 3 (each within the scatter of the next).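

In this assay, among these compounds, this is the first pair that differs in one place, and it gives a 1.1-fold lower number from compound 3 to compound 4 (0.05 log units; within the scatter) for dimethylamino in place of amino on a saturated ring carbon. At this position, the exchange therefore stays within the scatter, even though it adds 2 carbon atoms and takes the hydrogen-bond donors of the group from 1 to 0. No measurement shown here explains this result.

As far as these compounds go, whether a carboxylic acid or a longer chain on this ring carbon would give a step beyond the scatter remains open. A single pair also cannot show whether this step carries over to other compounds in the series.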